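The source may hold more compounds than are shown below. What is called first, only, known or untested is meant among the compounds shown, and "the series" means these compounds.

Working notes on the series in a functional assay on LNCaP cells (Homo sapiens) for cytotoxicity; a higher number here means that more compound is needed for the effect, a lower number that less compound is needed.

Compound 1 `CCC[C@@H](OC(C)=O)C1=C(Br)[C@@](C)(OC)OC1=O` gives 1.7 ug/mL in this assay, the highest of the two numbers available; the nearest number, that of compound 3, lies well beyond the scatter below it. Compound 3 `CCC[C@@H](O)C1=C(Br)/C(=C/Br)OC1=O` gives 0.2 ug/mL in this assay. Compound 2 `CCC[C@@H](O)C1=C(Br)/C(=C/I)OC1=O` gives < 0.1 ug/mL in this assay, which is a limit of the assay and not a number; it sits at the limit of < 0.1 ug/mL in this assay, at which 1 of the 3 values shown sits. Going by the values given here, the only measured step between neighbours, an at least 2.0-fold higher number from compound 2 to compound 3 (0.30 log units; that floor lies within the scatter), concerns the halogen on the double-bonded chain carbon and reaches only the floor of the scatter.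

Compound 4 `CCC[C@@H](OC(C)=O)C1=C(Br)[C@](OC)(C(Br)Br)OC1=O` differs from compound 1 by dibromomethyl in place of methyl on a saturated ring carbon. Among the compounds with values here, no measured step covers an exchange on that saturated ring carbon, and the step of an at least 2.0-fold higher number from compound 2 to compound 3 (0.30 log units; that floor lies within the scatter) changes a different position, so it gives no direct guide. With nothing pointing in either direction, the step of a 1.3-fold lower number from compound 1 to compound 4 (0.12 log units; within the scatter) is expected to stay within the scatter. Compound 4 is therefore estimated at 1.3 ug/mL in this assay, with a range from 0.4 ug/mL to 4 ug/mL.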

Compound 4, concentration for half-maximal effect: 4.5 ug/mL
For compound 4 the middle estimate is 3.5-fold (0.54 log units) below the measured one, outside the stated range (above it).
By their numbers in this assay, from the lowest: compound 3; then compound 1; then compound 4. At a limit, below all of these: compound 2.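

In this assay, going by these compounds alone, dibromomethyl in place of methyl on the saturated ring carbon gives a 2.6-fold higher number from compound 1 to compound 4 (0.42 log units; beyond the scatter), the first measured step at this position. This ring carbon is therefore not indifferent to the exchange: the step is modest, but more compound is needed for the effect with dibromomethyl there, a reading that rests on this single pair. Nothing measured among the data shown bears on the reason for this step.

Going by these compounds, whether bromomethyl, ethyl or a carboxylic acid on this ring carbon would give a number near that of compound 1 or that of compound 4 remains open. On these data alone, compound 2 and compound 3 differ from compound 1 and compound 4 in more than one place, so whether the exchange behaves alike on their structures also stays open.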